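This account rests on a few compounds, and the source may have more. Where it says the series, first, only, none or still open, it means among the compounds named here.

In a functional assay on MDA-MB-231 cells (Homo sapiens) for cytotoxicity, read by MTT assay, with a stated time of 72 h (a lower number here means a stronger inhibitor, a higher number a weaker inhibitor), compound 1 (`CN(C)CCCCCn1c2c(c3ccccc31)C(=O)c1c[n+]([O-])c3ccccc3c1C2=O`) gives 240 nM and compound 3 (`CC1(C)O[C@@H](CO)[C@H](Cn2cc(Cn3c4c(c5ccccc53)C(=O)c3c[n+]([O-])c5ccccc5c3C4=O)nn2)O1`) gives 680 nM on the same scale, while compound 2 (`O=C1c2c[n+]([O-])c3ccccc3c2C(=O)c2c1c1ccccc1n2CCCCN1CCNCC1`) gives 3310 nM as the highest of the three numbers. Compound 4 (`O=C1c2c[n+]([O-])c3ccccc3c2C(=O)c2c1c1ccccc1n2CCN1CCCCC1`) is still unmeasured, and the change leading to it is piperidin-1-yl in place of 2-(piperazin-1-yl)ethyl on a saturated chain carbon, two bonds along the chain from an aromatic nitrogen on a saturated chain carbon, two bonds along the chain from an aromatic nitrogen. Among the compounds with values here, only one measured step bears on this: a 14-fold higher number from compound 1 to compound 2 (1.14 log units; beyond the scatter) (large and beyond the scatter), with piperazin-1-yl in place of (dimethylamino)methyl. Compound 4 loses the piperazin-1-yl, so that step is expected to run partly in reverse. Compound 3 also carries no piperazin-1-yl and stands at 680 nM in this series. Piperidin-1-yl itself has no measured precedent here, which keeps the range wide. The expected step is a 4.7-fold lower number from compound 2 to compound 4 (0.67 log units; beyond the scatter) in this assay and it runs to a lower number, somewhat smaller in size than the measured one. For compound 4 the estimated value is 700 nM with an expected range from 220 nM to 2200 nM in this assay.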

Compound 4, half-maximal inhibitory concentration: 1050 nM
For compound 4 the middle estimate is 1.5-fold (0.18 log units) below the measured one, within the range that was stated.
By their numbers in this assay, from the lowest: compound 1; then compounds 3 and 4 (each within the scatter of the next); then compound 2.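

In this assay the change to piperidin-1-yl on a saturated chain carbon, two bonds along the chain from an aromatic nitrogen, gives a 3.2-fold lower number from compound 2 to compound 4 (0.50 log units; beyond the scatter) and so takes back only part of a 14-fold higher number from compound 1 to compound 2 (1.14 log units; beyond the scatter) in this series. Read one bond further out, the same change is 4-(piperazin-1-yl)butyl to 2-(piperidin-1-yl)ethyl, so ring and chain length move together in this step. The 3-(dimethylamino)propyl replaced in the other comparison still gives the lower number, with a 4.4-fold higher number from compound 1 to compound 4 (0.64 log units; beyond the scatter) beyond the scatter, and no measurement at hand accounts for either shift.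

Still open, on these data alone, is how much of the step belongs to the ring and how much to the chain length. A 4-(piperidin-1-yl)butyl chain on the shared core would separate the two.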